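The compounds below may be only part of what the source reports. "The series", "measured", "known", "first", "only" and "open" are said of these compounds alone.

Compound 1 `CCN(CC)c1cc2[nH]c(C3CCCCC3)nc2cc1NC(=O)OCC(F)(F)F` in an ADME assay on Vero cells (Chlorocebus sabaeus) for cytotoxicity, read by resazurin assay, with a stated time of 3 days (on this read-out lower numbers stand for stronger inhibition and higher numbers for weaker inhibition), gives > 100 ug/mL, which is a limit of the assay and not a number. Compound 2 `CN(C)c1cc2[nH]c(C3CCCCC3)nc2cc1NC(=O)OCC(F)(F)F` in this assay gives > 100 ug/mL, again a limit. Compound 3 `CCc1ccc(C(=O)Nc2cc3nc(C4CCCCC4)[nH]c3cc2N(C)C)cc1` in this assay gives > 100 ug/mL, again a limit.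

From compound 2 to compound 1 the change is diethylamino in place of dimethylamino on an aromatic carbon, and the step is a step that the two limits leave unreadable from compound 2 to compound 1. From compound 2 to compound 3 the change is 4-ethylphenyl in place of 2,2,2-trifluoroethoxy on a carbonyl carbon, and the step is a step that the two limits leave unreadable from compound 2 to compound 3. All three compounds sit at the limit of > 100 ug/mL in this assay, at which 3 of the 3 values shown sit, so neither step can be sized.

Compound 4 `CCc1ccc(C(=O)Nc2cc3nc(C4CCCCC4)[nH]c3cc2N(CC)CC)cc1` has not yet been measured. From compound 3 to compound 4 the change is diethylamino in place of dimethylamino on an aromatic carbon. This is the same kind of change as from compound 2 to compound 1, though the surroundings differ: here it is ortho to a large group, whereas in the earlier pair it is ortho to a ((2,2,2-trifluoroethoxy)carbonyl)amino group (9 heavy atoms). Compound 4 is expected to give 100 ug/mL in this assay. The step this estimate means, a number no higher from compound 3 to compound 4 (the limit leaves the size open), is expected to be small because the limit of > 100 ug/mL in this assay, at which 3 of the 3 values shown sit, holds for every measured compound.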

Compound 4, half-maximal inhibitory concentration: > 100 ug/mL
Compound 4 gave a limit, no number; the forecaster's own chance of this, stated with the estimate: 85%; the middle value lies on the limit itself.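

Compound 4 gives only a limit, as do compound 1 and compound 3, so neither new step, to compound 4 from compound 3 or from compound 1, can be read: the limit of > 100 ug/mL in this assay, at which 4 of the 4 values shown sit.

The compounds shown leave open whether any of them differs from another in this assay.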